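Swapping a Hexyl for a Cyclopropyl on a Shared Core

A few compounds are considered here, and "the series" means these few. Any claim that something is new, unique, unknown or untested is made for them only; others in the source may bear on it.

Of the compounds shown here, three have been tested so far in a functional assay on A-375 cells (Homo sapiens) for antiproliferative activity, read by MTT assay, with a stated time of 48 h; on this read-out lower numbers stand for stronger inhibition and higher numbers for weaker inhibition. Compound 1 `CCCCCCCc1nc(N)n(CC(=O)Nc2ccccc2)c1-c1ccccc1Br` gives 9200 nM in this assay. Compound 2 `Nc1nc(CC2CC2)c(-c2ccccc2Br)n1CC(=O)Nc1ccccc1` gives 5800 nM in this assay. Compound 3 `CCCCCCCc1nc(N)n(CC(=O)Nc2ccc(C)cc2)c1-c1ccccc1Br` gives 5200 nM in this assay, and its gaps to the other two compounds fall within the usual scatter of repeated measurements.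

Two single changes link these compounds. From compound 1 to compound 2 the change is cyclopropyl in place of hexyl on a saturated chain carbon bound to an aromatic carbon, and the step it made is a 1.6-fold lower number from compound 1 to compound 2 (0.20 log units; within the scatter). From compound 1 to compound 3 the change is methyl in place of hydrogen on an aromatic carbon, with the step of a 1.8-fold lower number from compound 1 to compound 3 (0.25 log units; within the scatter).

Compound 4 `Cc1ccc(NC(=O)Cn2c(N)nc(CC3CC3)c2-c2ccccc2Br)cc1` has not yet been measured in this assay. It differs from compound 3 by cyclopropyl in place of hexyl on a saturated chain carbon bound to an aromatic carbon. This is the same change already seen from compound 1 to compound 2, occurring twice among the compounds shown, and it sits at the same kind of place in both pairs. The cores of the two pairs differ only by the methyl described above.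

A step of similar size is expected for compound 4 in this assay, namely a 1.4-fold lower number from compound 3 to compound 4 (0.14 log units; within the scatter), because a 1.6-fold lower number from compound 1 to compound 2 (0.20 log units; within the scatter) stayed within the scatter. Compound 4 is therefore estimated at 3800 nM, with an expected range from 1800 nM to 8000 nM.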

Compound 4, half-maximal inhibitory concentration: 2600 nM
For compound 4 the middle estimate is 1.5-fold (0.16 log units) above the measured one; low and high end bracket the measured number.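

In this assay, the step for cyclopropyl in place of hexyl on the core carrying the extra methyl is a 2.0-fold lower number from compound 3 to compound 4 (0.30 log units; within the scatter), and it agrees with the same change on the core without that methyl: the same change on two cores in this assay, a 1.6-fold lower number (0.20 log units; within the scatter) from compound 1 to compound 2 and a 2.0-fold lower number (0.30 log units; within the scatter) from compound 3 to compound 4, 1.3-fold (0.10 log units) apart, within the scatter of two such steps. The other change, methyl in place of hydrogen on an aromatic carbon, is read with cyclopropyl already present as a 2.2-fold lower number from compound 2 to compound 4 (0.35 log units; beyond the scatter), a modest step that also agrees with its earlier counterpart: the same change on two cores in this assay, a 1.8-fold lower number (0.25 log units; within the scatter) from compound 1 to compound 3 and a 2.2-fold lower number (0.35 log units; beyond the scatter) from compound 2 to compound 4, 1.3-fold (0.10 log units) apart, within the scatter of two such steps. Within these four compounds, each change carried over from one core to the other with no difference larger than the scatter, but both comparisons rest on the same four numbers and on only two cores, and they show neither that the steps would hold on other cores nor why they take this size.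

The compounds shown leave open whether the same agreement would appear with an amine, a carboxylic acid or a shorter chain on a saturated chain carbon bound to an aromatic carbon. They also leave open whether a group such as chloro or methoxy, in place of the hydrogen on an aromatic carbon, would carry over in the same way.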